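Chloro for fluoro, carried from one core to a second

The compounds below may be only part of what the source reports. "The series", "measured", "known", "first", "only" and "open" are said of these compounds alone.

Compound 1 `CN(C)CCNc1nc(-c2ccc(NC(=O)Nc3ccc(F)cc3)cc2)nc2ccsc12` is the reference point of the set. In a functional assay on MDA-MB-231 cells (Homo sapiens) for cytotoxicity, read by MTT assay, with a stated time of 72 h (on this read-out lower numbers stand for stronger inhibition and higher numbers for weaker inhibition), compound 1 gives 540 nM. Compound 3 `CN(C)CCNc1nc(-c2ccc(NC(=O)Nc3ccc(Cl)cc3)cc2)nc2ccsc12` shares the core of compound 1 and differs from it by one change, (chloro in place of fluoro on an aromatic carbon). In this assay compound 3 gives 310 nM. That change gives a 1.7-fold lower number from compound 1 to compound 3 (0.24 log units; within the scatter), so on the core of compound 1 the swap moves the number only a little.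

Compound 2 `CN(C)CCNc1nc(-c2ccc(NC(=O)Nc3ccc(F)cc3)cc2)nc2c(Cl)c(Cl)sc12` carries a different core; the difference between the two cores is not broken down here. In this assay compound 2 gives 1240 nM, the highest of the three numbers, with compound 1 its nearest neighbour and compound 3 the furthest, both gaps beyond the scatter.

Compound 4 `CN(C)CCNc1nc(-c2ccc(NC(=O)Nc3ccc(Cl)cc3)cc2)nc2c(Cl)c(Cl)sc12` has not yet been measured. It stands to compound 2 as compound 3 stands to compound 1: the change is chloro in place of fluoro on an aromatic carbon, and its place line reads the same word for word as in the earlier pair, so this is the same change made on the core of compound 2.

Among the measured compounds shown here, the only guide to the step is the earlier pair, which showed a 1.7-fold lower number from compound 1 to compound 3 (0.24 log units; within the scatter). From compound 2 to compound 4 a step of about a 1.7-fold lower number from compound 2 to compound 4 (0.24 log units; within the scatter) is therefore expected, resting on that single precedent and on the value of compound 2, 1240 nM. Whether the second core answers the swap in the same way is not known from two compounds alone, so the range is kept wide.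

Compound 4 is estimated at 720 nM in this assay, with a likely span from 350 nM to 1500 nM.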

Compound 4, half-maximal inhibitory concentration: 870 nM
Beside the measured number, compound 4's estimate is 1.2-fold (0.08 log units) below it, within the range that was stated.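

On the core of compound 2 the swap gives a 1.4-fold lower number from compound 2 to compound 4 (0.15 log units; within the scatter), so here too the step stays small. Set side by side in this assay, the two steps agree within the scatter: the same change on two cores in this assay, a 1.7-fold lower number (0.24 log units; within the scatter) from compound 1 to compound 3 and a 1.4-fold lower number (0.15 log units; within the scatter) from compound 2 to compound 4, 1.2-fold (0.09 log units) apart, within the scatter of two such steps This shows that, across these two pairs, the change from 4-fluorophenyl to 4-chlorophenyl behaves alike on both cores, but since each step lies within the scatter, it does not show a real difference between the fluoro and chloro compounds on either core, and two pairs set no rule for any further core in the series.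

The compounds shown leave open whether a bromo, methyl or methoxy group on that same aromatic carbon would produce a step beyond the scatter on either core, and whether such a step would carry from one core to the other in the way this small one does. Among the compounds shown here, they also leave open how the series responds when the core carries only one chloro group, or when a longer chain or a cyclic amine takes the place of the basic side chain.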